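Fluoro for Hydrogen, Repeated on a Second Core

The source may report more compounds than this note shows. Statements on the series, on what has been measured and on what is new or still open speak of the compounds shown alone.

Measured compounds:
compound 1 `Clc1ncnc2c1ncn2Cc1ccccc1`: 3%
compound 2 `Fc1ccc(Cn2cnc3c(Cl)ncnc32)cc1`: 0%
compound 3 `c1ccc(Cc2[nH]cnc3ncnc2-3)cc1`: 1%

In an assay on isolated protein for inhibition of Rho-associated protein kinase 1 (Homo sapiens), tested at 30 uM (a higher number here means more inhibition at the concentration tested (going by the name of the read-out), a lower number less inhibition), compound 1 gives 3%. Compound 2 carries fluoro in place of hydrogen on an aromatic carbon, and in this assay compound 2 gives 0%, so the step of a number 3 percentage points lower from compound 1 to compound 2 (within the scatter) is within the scatter. Compound 3 has a different core; how that core differs from the core of compound 1 is not broken down here. In this assay compound 3 gives 1%, which stands within the scatter of both compound 1 and compound 2. Compound 4 `Fc1ccc(Cc2[nH]cnc3ncnc2-3)cc1` has not yet been measured; it differs from compound 3 by fluoro in place of hydrogen on an aromatic carbon, the same change that separates compound 1 from compound 2. Because a number 3 percentage points lower from compound 1 to compound 2 (within the scatter) was within the scatter, the step from compound 3 to compound 4 is expected to be no change at the digits printed from compound 3 to compound 4 (within the scatter). Compound 4 is therefore estimated at 1%, between -6% and 8%.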

Compound 4, a percentage reported as inhibition, at one concentration (the size of the read-out at that concentration, not a potency): 2%
Beside the measured number, compound 4's estimate is 1 percentage points below it; low and high end bracket the measured number.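

In this assay, the step of a number 1 percentage points higher from compound 3 to compound 4 (within the scatter) comes with fluoro in place of hydrogen on an aromatic carbon, and the same change on the other core gives a matching result: the same change on two cores in this assay, a number 3 percentage points lower (within the scatter) from compound 1 to compound 2 and a number 1 percentage points higher (within the scatter) from compound 3 to compound 4, 4 percentage points apart, within the scatter of two such steps. The change therefore carries from one core to the other only in the sense that it leaves the read-out within the scatter on both. This does not show that fluoro has any effect of its own on either core, nor how the change would behave on a compound with clear inhibition, since all four compounds show very little at the concentration tested.

The compounds shown leave open whether any other group at that ring position, such as an amine, a methoxy group or a carboxylic acid, would give a clearer read-out. Within the data shown here, they also leave open whether the benzyl group matters at all, as no compound here replaces it with a longer chain.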